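The source may report more compounds than this note shows. Statements on the series, on what has been measured and on what is new or still open speak of the compounds shown alone.

Of the compounds shown here, two that share one core have been measured in a functional assay on SF-539 cells (Homo sapiens) for inhibition, read by sulforhodamine B assay, with a stated time of 48 h; on this read-out lower numbers stand for stronger inhibition of growth and higher numbers for weaker inhibition of growth. Compound 1 `O=C(Nc1cccc(-n2cc(-c3ccncc3)c(-c3ccc(Cl)c(O)c3)n2)c1)Nc1cccc(C(F)(F)F)c1` gives 11600 nM in this assay. Compound 2 `COc1cc(-c2nn(-c3cccc(NC(=O)Nc4ccc(Cl)c(Cl)c4)c3)cc2-c2ccncc2)ccc1Cl` gives 3080 nM, the lower of the two numbers; compound 1 stands well above it, beyond the usual scatter, so compound 2 is the stronger growth inhibitor of the pair. Compound 3 `O=C(Nc1cccc(-n2cc(-c3ccncc3)c(-c3ccc(Cl)c(O)c3)n2)c1)Nc1ccc(Cl)c(Cl)c1` has not yet been measured. It differs from compound 2 in one place: hydrogen in place of methyl on an oxygen on an aromatic ring. For the measured compounds named here, no measured pair shows this change on its own; compound 1 carries the hydroxy group but differs from compound 2 in a second place as well, so its number cannot be read as this change alone. The step from compound 2 to compound 3 is expected to be modest, leaning toward weaker inhibition, a 1.6-fold higher number from compound 2 to compound 3 (0.21 log units; within the scatter). Compound 3 is estimated at 5000 nM, within a range of 2000 nM to 15000 nM.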

Compound 3, concentration for total growth inhibition: 8970 nM
Compound 3: middle estimate off by 1.8-fold (0.25 log units), on the low side; low and high end bracket the measured number.
By their numbers in this assay, from the lowest: compound 2; then compounds 3 and 1 (each within the scatter of the next).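

In this assay, the change from methoxy to hydroxy on the aromatic ring can now be read on its own (a 2.9-fold higher number from compound 2 to compound 3 (0.46 log units; beyond the scatter)). In this pair, then, removing the methyl from that oxygen weakens growth inhibition. The other new pair puts 3,4-dichlorophenyl in place of 3-(trifluoromethyl)phenyl on an amide-type nitrogen (a 1.3-fold lower number from compound 1 to compound 3 (0.11 log units; within the scatter)), so with the hydroxy group present, this assay does not separate those two groups. Nothing measured here explains the effect of the methoxy-to-hydroxy change.

As far as these compounds go, a longer chain such as ethoxy, or an amine, in place of the methoxy group remains open. Also open, from the compounds shown here alone, is whether the same methoxy-to-hydroxy step holds when 3-(trifluoromethyl)phenyl sits on the amide-type nitrogen.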